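The compounds below may be only part of what the source reports. "The series", "measured", "known", "first", "only" and "open" are said of these compounds alone.

Measured compounds:

Compound 1 `C=Cc1cccc(-c2[nH]c3cc(OC)ccc3c(=O)c2C(=O)OCC)c1`. In an ADME assay on HepG2 cells (Homo sapiens) for cytotoxicity, read by luminescence, with a stated time of 72 h (on this read-out lower numbers stand for an effect already at smaller amounts and higher numbers for an effect only at larger amounts of compound), compound 1 gives > 21500 nM, which is a limit of the assay and not a number.
Compound 2 `CCOC(=O)c1c(-c2cccc(C(F)(F)F)c2)[nH]c2cc(OC)ccc2c1=O`. In this assay compound 2 gives > 21500 nM, again a limit of the assay.
Compound 3 `CCOC(=O)c1c(-c2cccc(F)c2)[nH]c2cc(OC)ccc2c1=O`. In this assay compound 3 gives > 21500 nM, again a limit of the assay.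

Compound 1 therefore stands nowhere on a scale of numbers: it sits at the limit, and so does every other measured member of the series, as the limit of > 21500 nM in this assay, at which 3 of the 3 values shown sit, shows.

The unmeasured compound 4 `CCOC(=O)c1c(-c2cccc(Br)c2)[nH]c2cc(OC)ccc2c1=O` differs from compound 1 by bromo in place of vinyl on an aromatic carbon.

Among the measured compounds shown here, three measured steps touch the same position of the same ring: a step that the two limits leave unreadable from compound 1 to compound 2; a step that the two limits leave unreadable from compound 1 to compound 3; a step that the two limits leave unreadable from compound 2 to compound 3. None of them has a readable size, because every value in the limit of > 21500 nM in this assay, at which 3 of the 3 values shown sit, is a limit. For the measured compounds named here, they show only that changing the group at this place has not so far brought any value below the limit.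

For compound 4 the expectation is the same: no effect within the measured range, so the step that the limit leaves unreadable from compound 1 to compound 4 is expected to remain unreadable. The estimate for compound 4 in this assay is 40000 nM, expected to lie between 21500 nM and 200000 nM, most likely reported again as a limit.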

Compound 4, half-maximal effective concentration: > 21500 nM
Compound 4: a limit, no number; the forecaster's own chance of this, stated with the estimate: 85%; the middle value is on the limit's open side.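

Compound 4 adds no readable step: its comparisons with compound 1, compound 2 and compound 3 in this assay cannot be sized, because each value is a limit of the assay and not a number: the limit of > 21500 nM in this assay, at which 4 of the 4 values shown sit.

The compounds shown leave open whether any group at this place brings an effect within the measured range.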